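A Second Methyl on the Aniline Ring of Compound 1

This account rests on a few compounds, and the source may have more. Where it says the series, first, only, none or still open, it means among the compounds named here.

Compound 1 `Cc1ccc(NS(=O)(=O)C2CCCCC2=O)cc1` gives -3.55%
Compound 2 `O=C1CCCCC1S(=O)(=O)Nc1cccc(C(F)(F)F)c1` gives 17%
Compound 3 `Cc1cccc(S(=O)(=O)C2CCCCCC2=O)c1C` gives 22.9%

Of the compounds shown here, three have been measured in a functional assay on HL-60 cells (Homo sapiens) for antiproliferative activity, read by MTT assay, tested at 100 ug/mL; a lower number here means less inhibition, a higher number more inhibition at the concentration tested (going by the name of the read-out). Compound 1 gives the lowest of the three numbers; compound 2 is the nearest to it, with a number beyond the scatter above it, and compound 3 lies furthest away, also beyond the scatter. Compound 4 `Cc1ccc(NS(=O)(=O)C2CCCCC2=O)c(C)c1` differs from compound 1 by one change only: methyl in place of hydrogen on an aromatic carbon. Within the data shown here, no two measured compounds differ in just one place, so there is no measured step to lean on for this change. The shift is expected to be small, a number 6.6 percentage points higher from compound 1 to compound 4 (within the scatter), and may well stay within the scatter. Compound 4 is therefore estimated at 3%, in a range from -12% to 20%.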

Compound 4, a percentage reported as inhibition, at one concentration (the size of the read-out at that concentration, not a potency): 12.2%
Compound 4: the middle estimate sits 9.2 percentage points below what was measured, within the range that was stated.
By their numbers in this assay, from the lowest: compound 1; then compounds 4, 2 and 3 (each within the scatter of the next, the first and the last beyond it).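

Placing methyl in place of hydrogen on an aromatic carbon, ortho to a large group, gives the first single-change step in this assay: the result is a number 15.8 percentage points higher from compound 1 to compound 4 (beyond the scatter) and shows that this position responds to even one added carbon. The step is modest, but it clears the usual scatter. Nothing measured here explains the shift.

From the compounds shown here alone, whether an ethyl group, a methoxy group or a chlorine atom at this place would move the number as far remains open. So does whether the same methyl would have a similar effect on compounds 2 or 3.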